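Cytotoxicity of Thiourea Ethers: Pyrrolyl Replaces Diethylamino

The source may report more compounds than this note shows. Statements on the series, on what has been measured and on what is new or still open speak of the compounds shown alone.

Compound 1 `NC(=S)Nc1cccc(OCCCCCOc2ccc(Br)cc2)c1`: 19000 nM
Compound 2 `NC(=S)Nc1cccc(OCCCCCOc2ccc(C(=O)O)cc2)c1`: only a limit, > 50000 nM
Compound 3 `CCN(CC)c1ccc(OCCCCCOc2cccc(NC(N)=S)c2)cc1`: only a limit, > 50000 nM

Of the compounds shown here, three sharing the core of compound 1 have been tested in an ADME assay on Ava5 cells (Homo sapiens) for cytotoxicity; on this read-out lower numbers stand for higher toxicity in this test and higher numbers for lower toxicity in this test. Compound 1 gives a measured number. For compound 2 the assay reports only a limit. For compound 3 the assay likewise reports only a limit, so compound 3 sits at the limit of > 50000 nM in this assay, at which 2 of the 3 values shown sit, and the data say only that its toxicity does not reach that concentration.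

The change to compound 4 `NC(=S)Nc1cccc(OCCCCCOc2ccc(-n3cccc3)cc2)c1` is 1H-pyrrol-1-yl in place of diethylamino on an aromatic carbon, on an aromatic carbon of a six-membered aromatic ring of carbon only, para to a large group. The measured steps at the same place are an at least 2.6-fold higher number from compound 1 to compound 2 (0.42 log units; beyond the scatter) and an at least 2.6-fold higher number from compound 1 to compound 3 (0.42 log units; beyond the scatter); both replacements of bromo lowered toxicity at least modestly. The step that the two limits leave unreadable from compound 2 to compound 3 has no readable size. Among the compounds with values here, no measured step introduces 1H-pyrrol-1-yl, so there is no direct guide for this change. Starting from a limit, a further rise could not be seen; a fall back toward compound 1 is possible but not shown.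

Compound 4 is therefore expected to remain near the limit, with an at least 1.2-fold lower number from compound 3 to compound 4 (0.09 log units; that floor lies within the scatter) expected to be small or unreadable. The estimate for compound 4 is 40000 nM, between 15000 nM and 60000 nM.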

Compound 4, half-maximal cytotoxic concentration: > 50000 nM
Compound 4: a limit, no number; the forecaster's own chance of this, stated with the estimate: 50%; middle value at least 1.2-fold (0.09 log units) from the limit.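

In this assay, 1H-pyrrol-1-yl becomes the third group, after carboxy and diethylamino, whose replacement of bromo on this aromatic carbon, para to a large group, gives a step beyond the scatter (an at least 2.6-fold higher number from compound 1 to compound 4 (0.42 log units; beyond the scatter)). Diethylamino and 1H-pyrrol-1-yl are matched in their heavy atoms and differ in that the entering group carries a five-membered aromatic ring, yet compound 4 still gives only a limit and no number. The steps among compound 2, compound 3 and compound 4 cannot be read, and all three compounds share the same limit: the limit of > 50000 nM in this assay, at which 3 of the 4 values shown sit.

Going by these compounds, how far these three compounds lie beyond that limit remains open, so the data cannot place them in any order or show whether the ring of 1H-pyrrol-1-yl changes toxicity relative to diethylamino. On these data alone, it also remains open whether a halogen such as chloro, a small ether such as methoxy, or a shorter chain in the shared core would give a measured number closer to that of compound 1.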